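The source may hold more compounds than are shown below. What is called first, only, known or untested is meant among the compounds shown, and "the series" means these compounds.

Working notes on the series in an ADME assay on MT4 cells (Homo sapiens) for cytotoxicity, read by MTT assay, with a stated time of 96 h; a lower number here means that less compound is tolerated, a higher number that more compound is tolerated.

Compound 1 `Fc1ccc(F)c(/N=N/N2CCCC2)c1` reads > 100000 nM, which is a limit of the assay and not a number. Compound 3 `Brc1ccc(/N=N/N2CCCC2)cc1` reads > 100000 nM, also a limit. For the measured compounds named here, compound 2 `Cc1c(/N=N/c2cccc(C(F)(F)F)c2)ccc(NC[C@@H]2CCCN3CCCC[C@H]23)c1C` gives 77000 nM, the only actual number in the set.

Compound 4 `Cc1c(/N=N/c2ccccc2)ccc(NC[C@@H]2CCCN3CCCC[C@H]23)c1C` is still to be measured in this assay. Its structure departs from compound 2 in one place: hydrogen in place of trifluoromethyl on an aromatic carbon. In words, hydrogen stands in place of trifluoromethyl on an aromatic carbon, and 3-(trifluoromethyl)phenyl becomes phenyl.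

Going by the values given here, no pair of measured compounds differs in one place, so the size of this change has no direct precedent. The expectation therefore rests on compound 2 at 77000 nM alone, and it is for no change beyond the usual scatter, in either direction. The estimated 1.0-fold lower number from compound 2 to compound 4 (0.01 log units; within the scatter) is small on that basis. Compound 4 could also read as a limit rather than a number, the case noted in the limit of > 100000 nM in this assay, at which 2 of the 3 values shown sit. For compound 4 the expected value is 75000 nM, with an estimated range of 35000 nM to 100000 nM.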

Compound 4, half-maximal cytotoxic concentration: 31000 nM
Compound 4: middle estimate off by 2.4-fold (0.38 log units), on the high side, and the stated range ends above it.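

In this assay, for the compounds shown here, a 2.5-fold lower number from compound 2 to compound 4 (0.40 log units; beyond the scatter) gives the first reading of a change at this position: with hydrogen in place of trifluoromethyl, 3-(trifluoromethyl)phenyl becomes phenyl and less compound is tolerated. The step is modest and beyond the scatter, but it rests on this single pair, so it gives a direction for this one change on this core and no general rule for the position. Compound 2 and compound 4 both read as numbers, not as limits, so this pair can be compared directly, unlike the other compounds in the series: the limit of > 100000 nM in this assay, at which 2 of the 4 values shown sit.

Whether a nitrile, a methoxy group, an amine or a carboxylic acid at the same place would fall with compound 2, with compound 4 or outside both remains open, as does the reason for the step itself. Also open, going by these compounds, is whether the same change would act alike on another core, since compound 1 and compound 3 differ from this pair in more than one place and say nothing about it.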